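The source may hold more compounds than are shown below. What is called first, only, known or untested is meant among the compounds shown, and "the series" means these compounds.

Three measured compounds share one core and were tested for how much of each is tolerated by lung-derived cells. In a toxicity assay on A549 cells (Homo sapiens) for cytotoxicity, read by luminescence and CellTiter-Glo, with a stated time of 48 h (a lower number here means that less compound is tolerated, a higher number that more compound is tolerated), compound 1 `CCCCOc1ccc(-c2nc3ncccn3c2NC(C)(C)CC(C)(C)C)cc1` gives 29000 nM, and compound 2 `CCCCOc1ccc(-c2c(NC(C)(C)CC(C)(C)C)nc3ncccn23)cc1` gives 49000 nM. Compound 3 `O=C(O)CCCOc1ccc(-c2nc3ncccn3c2NC2CCCCC2)cc1` reaches only a limit of this assay, reported as > 100000 nM. Compound 3 thus sits at the limit of > 100000 nM in this assay, at which 1 of the 3 values shown sits, so its true value is not known as a number.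

Compound 4 `c1cnc2nc(-c3ccc(OC4CCCC4)cc3)c(NC3CCCCC3)n2c1` differs from compound 3 by cyclopentyl in place of 3-carboxypropyl on an oxygen on an aromatic ring. Going by the values given here, no measured pair shows this change, so the expected step is an estimate: a move to less tolerated, beyond the scatter, of about an at least 3.3-fold lower number from compound 3 to compound 4 (0.52 log units; beyond the scatter). Compound 4 is expected to give 30000 nM, within a range from 8000 nM to 100000 nM.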

Compound 4, half-maximal cytotoxic concentration: 39000 nM
Compound 4: the middle estimate sits 1.3-fold (0.11 log units) below what was measured; low and high end bracket the measured number.
By their numbers in this assay, from the lowest: compounds 1, 4 and 2 (each within the scatter of the next). At a limit, above all of these: compound 3.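

Going by these compounds alone, replacing 3-carboxypropyl with cyclopentyl on an oxygen on an aromatic ring gives the first readable change at this position in this assay, with an at least 2.5-fold lower number from compound 3 to compound 4 (0.40 log units; beyond the scatter). Less compound is therefore tolerated with cyclopentyl on this oxygen than with 3-carboxypropyl. Compound 3 stands at a limit, so the full size of this step remains unknown: the limit of > 100000 nM in this assay, at which 1 of the 4 values shown sits.

The compounds shown leave open whether the carboxylic acid or the rest of the chain sets this difference. An ester or an amine at the end of the same chain on this oxygen could separate the two.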